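The source may report more compounds than this note shows. Statements on the series, on what has been measured and on what is new or still open speak of the compounds shown alone.

Of the compounds shown here, three sharing one core have been measured. Compound 1 `CCC(=O)N1CCN(Cc2nc3ccccc3n2Cc2cccc(C)c2)CC1` carries an ethyl group on the carbonyl carbon and in an assay on isolated protein for inhibition of aldehyde dehydrogenase 1A1 (Homo sapiens), read by spectrophotometry, tested at 10 uM (on this read-out lower numbers stand for less inhibition and higher numbers for more inhibition at the one concentration tested (going by the name of the read-out)), compound 1 gives 85.1%. Compound 2 `Cc1ccc(C(=O)N2CCN(Cc3nc4ccccc4n3Cc3cccc(C)c3)CC2)cc1` carries a 4-methylphenyl there instead, and in this assay compound 2 gives 64.9%, the step being a number 20.2 percentage points lower from compound 1 to compound 2 (beyond the scatter). Compound 3 `Cc1cccc(Cn2c(CN3CCN(C(=O)c4ccc(F)cc4)CC3)nc3ccccc32)c1` carries a 4-fluorophenyl on the carbonyl carbon; in this assay compound 3 gives 27.1%, which is the lowest of the three numbers, below compound 2 by a number 37.8 percentage points lower from compound 2 to compound 3 (beyond the scatter) and below compound 1 by a number 58 percentage points lower from compound 1 to compound 3 (beyond the scatter).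

Compound 4 `Cc1cccc(Cn2c(CN3CCN(C(=O)c4ccc(C#N)cc4)CC3)nc3ccccc32)c1` has not been measured. It differs from compound 3 by cyano in place of fluoro on an aromatic carbon. For the measured compounds named here, no measured step replaces fluoro with cyano, so the nearest guides are indirect: the exchange of methyl for fluoro on the same aromatic carbon, a number 37.8 percentage points lower from compound 2 to compound 3 (beyond the scatter), and the two steps from ethyl to an aryl group on the carbonyl carbon, a number 20.2 percentage points lower from compound 1 to compound 2 (beyond the scatter) and a number 58 percentage points lower from compound 1 to compound 3 (beyond the scatter), all of which point downward. These steps do not show whether a cyano group would move the number either way, so for compound 4 a change within the scatter is expected, a number 2.9 percentage points higher from compound 3 to compound 4 (within the scatter). The estimate for compound 4 in this assay is 30%, in a range from 10% to 55%.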

Compound 4, a percentage reported as inhibition, at one concentration (the size of the read-out at that concentration, not a potency): 20.8%
Compound 4: middle estimate off by 9.2 percentage points, on the high side; measured number inside the range.
By their numbers in this assay, from the lowest: compounds 4 and 3 (each within the scatter of the next); then compound 2; then compound 1.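

In this assay, the exchange of fluoro for cyano on the aromatic carbon para to a large group gives a number 6.3 percentage points lower from compound 3 to compound 4 (within the scatter), so the two groups cannot be told apart at this position, although cyano brings one more heavy atom and a hydrogen-bond acceptor. Set against methyl at the same place, cyano gives a number 44.1 percentage points lower from compound 2 to compound 4 (beyond the scatter), a large step that places compound 4 with compound 3 and leaves compound 2, the methyl compound, apart from both. Against the ethyl group on the carbonyl carbon, the 4-cyanophenyl group gives a number 64.3 percentage points lower from compound 1 to compound 4 (beyond the scatter), so among the three aryl compounds, the size of the step away from ethyl depends on the group at this aromatic carbon, with methyl giving the smaller step and fluoro and cyano the larger ones.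

No evidence at hand accounts for this result. As far as these compounds go, it remains open whether an amine, a carboxylic acid or a methoxy group at this aromatic carbon would stand with methyl or with fluoro and cyano, and whether a longer chain in place of the ethyl group would hold the number seen for compound 1.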